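A Single Weak Inhibitor and Its Untested Neighbour

This account rests on a few compounds, and the source may have more. Where it says the series, first, only, none or still open, it means among the compounds named here.

Measured compounds:
Compound 1 `CC(C)(C)OC(=O)N1CCN(C(=S)SCc2cn(-c3ccccc3F)nn2)CC1`, 89600 nM
Compound 2 `COc1cc(Cn2cc(CSC(=S)N3CCNCC3)nn2)cc(OC)c1OC`, "not determined" (no result reported)
Compound 3 `S=C(SCc1cn(Cc2ccc(Cl)c(Cl)c2)nn1)N1CCNCC1`, "not determined" (no result reported)

Among the measured compounds shown here, only one number is available. In a functional assay on MCF7 cells (Homo sapiens) for inhibition, read by MTT assay, with a stated time of 72 h (a lower number here means a stronger inhibitor, a higher number a weaker inhibitor), compound 1 gives 89600 nM, a weak result, far from what a potent inhibitor would show. For the measured compounds named here, compound 2 and compound 3 share the same thiocarbamoyl-piperazine motif but carry no reported result, so nothing can be said about how they compare with compound 1, and no step between measured compounds can be drawn.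

Compound 4 `Cc1ccc(-n2cc(CSC(=S)N3CCN(C(=O)OC(C)(C)C)CC3)nn2)cc1` is the untested compound. Its difference from compound 1 is a small swap on the outer aromatic ring: 4-methylphenyl in place of 2-fluorophenyl on an aromatic nitrogen. Both groups that leave and enter have the same number of heavy atoms, no hydrogen-bond donors or acceptors, and no charge, so the change is a modest one at the edge of the molecule.

Going by the values given here, with no measured pair to calibrate against, the expected step in this assay from compound 1 to compound 4 is small, in either direction, and most likely not beyond the usual scatter; the estimated step is a 1.1-fold lower number from compound 1 to compound 4 (0.05 log units; within the scatter). Compound 4 is therefore expected to land near compound 1, at about 80000 nM, within a range from 30000 nM to 250000 nM.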

Compound 4, half-maximal inhibitory concentration: 74200 nM
Compound 4: the middle estimate sits 1.1-fold (0.03 log units) above what was measured, within the range that was stated.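

The new number gives this position its first measured comparison. In this assay, placing 4-methylphenyl in place of 2-fluorophenyl on the aromatic nitrogen gives a 1.2-fold lower number from compound 1 to compound 4 (0.08 log units; within the scatter), so the two compounds cannot be told apart, and this position accepts either group with no readable shift in the result. The swap removes the fluorine and adds a methyl group at a different place on the phenyl ring, so this single comparison cannot separate the effect of the group's identity from that of its location, and no measurement shown here explains the result.

From the compounds shown here alone, compound 2 and compound 3 carry no numbers, so any steps involving them cannot be read, and the role of the rest of the molecule remains unknown. Going by these compounds, it also remains open whether a more different group at this position, such as a phenyl ring bearing a carboxylic acid or an amine, would give a step beyond the scatter, or whether the result stays this weak across such changes.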